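Replacing Ethyl with a Saturated Ring on the Shared Core

A few compounds are considered here, and "the series" means these few. Any claim that something is new, unique, unknown or untested is made for them only; others in the source may bear on it.

Compound 3 `CCc1nc2c(-c3ccnc(OC)c3)cnn2cc1OC` gives 960 nM in an assay on isolated protein for inhibition of activin receptor type-2A (Homo sapiens), read by 33P incorporation, with a stated time of 20 min, in the presence of a further agent that is not named here; a lower number here means a stronger inhibitor, a higher number a weaker inhibitor. Compound 2 `CNc1nc2c(-c3ccnc(OC)c3)cnn2cc1C` gives 1300 nM in this assay, within the scatter of compound 3, while compound 1 `C=Cc1cn2ncc(-c3ccnc(OC)c3)c2nc1NC` gives 190 nM, a gap from compound 3 that lies beyond the scatter. Compound 4 `COc1cc(-c2cnn3cc(OC)c([C@@H]4COC(C)(C)C4)nc23)ccn1` differs from compound 3 by a group of 7 heavy atoms (6 carbon, 1 oxygen; one five-membered non-aromatic ring with 1 hetero atom) in place of a group of 2 heavy atoms (2 carbon; no ring), on an aromatic carbon. For the measured compounds named here, the only measured step at this position is a 6.8-fold higher number from compound 1 to compound 2 (0.84 log units; beyond the scatter), which shows that the group there can move the number. Going by the values given here, no measured step shows whether a larger group helps or hurts, so the estimate stays cautious. The step expected from this change is a 1.6-fold lower number from compound 3 to compound 4 (0.20 log units; within the scatter), a lean toward a lower number. Compound 4 is therefore estimated at 600 nM, within 150 nM to 2500 nM.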

Compound 4, half-maximal inhibitory concentration: 5300 nM
Compound 4: middle estimate off by 8.8-fold (0.95 log units), on the low side, outside the stated range (above it).
By their numbers in this assay, from the lowest: compound 1; then compounds 3 and 2 (each within the scatter of the next); then compound 4.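

The change on this aromatic carbon brings a 5.5-fold higher number from compound 3 to compound 4 (0.74 log units; beyond the scatter) in this assay. This gives the first measured direction for a larger group here: compound 4, with its saturated oxygen-containing ring, is a weaker inhibitor than compound 3, with its ethyl. Nothing available explains this step.

The compounds shown leave open whether the higher number goes with the size of the group, its ring, or its ring oxygen; a cyclopentyl ring or a propyl chain at this carbon would help separate these. From the compounds shown here alone, the opposite configuration at the defined stereocentre also remains open.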